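Ethoxy for methoxy on the anilide of an inactive pair

The source may hold more compounds than are shown below. What is called first, only, known or untested is meant among the compounds shown, and "the series" means these compounds.

Measured in an ADME assay on SW480 cells (Homo sapiens) for cytotoxicity, read by MTT assay, with a stated time of 72 h; on this read-out higher numbers stand for weaker inhibition and lower numbers for stronger inhibition:
compound 1 `COc1ccc(NC(=O)c2cccc(/C=C3\CC(=O)N(c4ccccc4)C3=O)c2)cc1`: > 100000 nM
compound 2 `COc1ccc(NC(=O)c2cccc(/C=C3\CC(=O)N(c4ccc(C)cc4)C3=O)c2)cc1`: 93000 nM

Compound 1 gives > 100000 nM in this assay, which is a limit of the assay and not a number. Compound 2 gives 93000 nM. Going by the values given here, the only measured step, an at least 1.0-fold lower number from compound 1 to compound 2 (0.03 log units; that floor lies within the scatter), starts from the limit of > 100000 nM in this assay, at which 1 of the 2 values shown sits, so its size is only a floor, and that floor lies within the scatter. It concerns a methyl on an aromatic carbon of the phenyl on the imide nitrogen, not the anilide side.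

Compound 3 `CCOc1ccc(NC(=O)c2cccc(/C=C3\CC(=O)N(c4ccccc4)C3=O)c2)cc1` differs from compound 1 by methyl in place of hydrogen on a saturated chain carbon bound to an oxygen on an aromatic ring. Among the compounds with values here, no measured step touches this place, so the measured pair offers no direction for it. Compound 1 stands at the limit, and there is no number from which a measurable step could start.

Compound 3 is therefore expected to stay in the same region, with a step of a number no higher from compound 1 to compound 3 (the limit leaves the size open) expected. The estimate for compound 3 is 100000 nM, in the range 50000 nM to 200000 nM, and a limit rather than a number is the more likely report.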

Compound 3, half-maximal inhibitory concentration: 91500 nM
Estimate against measurement, compound 3: 1.1-fold (0.04 log units) above; measured number inside the range.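

The change from 4-methoxyphenyl to 4-ethoxyphenyl is the only change on the anilide side among the compounds shown, and in this assay it reads as an at least 1.0-fold lower number from compound 1 to compound 3 (0.03 log units; that floor lies within the scatter). Only a floor can be read for this step, because it starts from a limit of the assay: the limit of > 100000 nM in this assay, at which 1 of the 3 values shown sits.

What this adds for the position is modest: with the added methyl on the saturated chain carbon bound to the oxygen, compound 3 gives 91500 nM, a number rather than a limit, but the change shows no gain that can be told apart from the scatter.

The compounds shown leave open whether a longer chain such as propoxy, or an amine in place of the ethoxy group, would give a step beyond the scatter at this position. They also leave open what the ethoxy group does when the phenyl on the imide nitrogen carries a methyl, a combination that would show whether the two changes together move the number in this assay.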